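A few compounds are considered here, and "the series" means these few. Any claim that something is new, unique, unknown or untested is made for them only; others in the source may bear on it.

Measured so far:
compound 1, `COC(=O)c1cccc(CN(CCCCC(=O)O)C[C@H]2O[C@@H](n3cnc4c(N)ncnc43)[C@H](O)[C@@H]2O)c1`: > 250000 nM
compound 2, `NC(=O)CCCN(Cc1ccc2ccccc2c1)C[C@H]1O[C@@H](n2cnc3c(N)ncnc32)[C@H](O)[C@@H]1O`: 112000 nM

Among the compounds with values here, in an assay on cells for inhibition of Nicotinamide N-methyltransferase (Homo sapiens), with stated times of 10 min and 30 min (on this read-out higher numbers stand for weaker inhibition and lower numbers for stronger inhibition), compound 2 gives 112000 nM, the only numerical value in this small set. Compound 1 returns only a limit in this assay, > 250000 nM; (the limit of > 250000 nM in this assay, at which 1 of the 2 values shown sits). Within the data shown here, no step between two measured compounds that differ in a single place is available, so these two values show only that compound 2 yields a number where compound 1 does not.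

Compound 3, `Nc1ncnc2c1ncn2[C@@H]1O[C@H](CN(CCCCC(=O)O)Cc2ccc3ccccc3c2)[C@@H](O)[C@H]1O`, has not yet been measured in this assay. It differs from compound 2 by carboxymethyl in place of carbamoyl on a saturated chain carbon, three bonds along the chain from an amine nitrogen. With no measured step of this kind in the set, the direction cannot be read from the data, and the estimate rests on compound 2 alone. For compound 3 the expected step is a 1.6-fold higher number from compound 2 to compound 3 (0.21 log units; within the scatter), a modest shift toward weaker inhibition that may not exceed the usual scatter, with a real chance that the assay reports only a limit. For compound 3 in this assay the expected value is 180000 nM, in the range 70000 nM to 450000 nM.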

Compound 3, half-maximal inhibitory concentration: > 250000 nM
Compound 3 gave a limit, no number; the forecaster's own chance of this, stated with the estimate: 40%; middle value at least 1.3-fold (0.14 log units) from the limit.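

In this assay, within the data shown here, carboxymethyl in place of carbamoyl on a saturated chain carbon, three bonds along the chain from an amine nitrogen, gives an at least 2.2-fold higher number from compound 2 to compound 3 (0.34 log units; beyond the scatter), the first readable step and one that lies beyond the scatter. Compound 3 gives a limit, > 250000 nM, and not a number, so this position has now shown that the change from 3-carbamoylpropyl to 4-carboxybutyl does not retain the measurable inhibition of compound 2. The step from compound 1 to compound 3 cannot be read, and the only numerical value still belongs to the compound with the carbamoyl end, while the rest of the set sits at the limit: the limit of > 250000 nM in this assay, at which 2 of the 3 values shown sit.

Going by these compounds, how far compound 3 lies past its limit remains open, so the step has a lower bound but no upper one. The change alters the end group and the chain together, and a 3-carboxypropyl group, a 4-carbamoylbutyl group or a chain ending in an amine at this position would be needed to tell those contributions apart.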